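This account rests on a few compounds, and the source may have more. Where it says the series, first, only, none or still open, it means among the compounds named here.

Compound 1, with the structure `CN1C[C@H](C(=O)Nc2ccc(C#N)cc2)[C@@H](c2ccc(/C=C/C(=O)Nc3ccccc3N)cc2)C1`, is the starting point of this comparison. Among the compounds with values here, in an in vitro ADME assay on microsomes from liver (Homo sapiens) for pharmacokinetics, read by LC-MS, with a stated time of 10 min, tested at 1 uM (on this read-out higher numbers stand for fast clearance and lower numbers for slow clearance), compound 1 gives 1 mL/min/kg, the lowest of the three numbers measured so far. Two changes at the same amide-type nitrogen have already been measured. Compound 2, `CN1C[C@H](C(=O)Nc2ccc(C3CC3)cc2)[C@@H](c2ccc(/C=C/C(=O)Nc3ccccc3N)cc2)C1`, gives 12 mL/min/kg in this assay, and compound 3, `CN1C[C@H](C(=O)Nc2ccc(Cl)c(Cl)c2)[C@@H](c2ccc(/C=C/C(=O)Nc3ccccc3N)cc2)C1`, gives 14 mL/min/kg. The step of a 12-fold higher number from compound 1 to compound 2 (1.08 log units; beyond the scatter) and the step of a 14-fold higher number from compound 1 to compound 3 (1.15 log units; beyond the scatter) both run in the same direction, whereas the step of a 1.2-fold higher number from compound 2 to compound 3 (0.07 log units; within the scatter) is too small to read as a real difference.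

Compound 4, `CC(C)NC(=O)[C@H]1CN(C)C[C@@H]1c1ccc(/C=C/C(=O)Nc2ccccc2N)cc1`, has not yet been measured. It differs from compound 1 in one place: isopropyl in place of 4-cyanophenyl on an amide-type nitrogen. Both measured steps away from compound 1 replaced the cyano-bearing group and raised the number far beyond the scatter, so a rise is expected here as well. However, neither of those steps removed the whole aryl ring, so how far the number moves is uncertain. Compound 4 is therefore expected to give about 6 mL/min/kg, with a range from 2 mL/min/kg to 18 mL/min/kg. This estimate corresponds to an expected step of a 6.0-fold higher number from compound 1 to compound 4 (0.78 log units; beyond the scatter).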

Compound 4, clearance: 8 mL/min/kg
Compound 4: the middle estimate sits 1.3-fold (0.12 log units) below what was measured; measured number inside the range.
By their numbers in this assay, from the lowest: compound 1; then compounds 4, 2 and 3 (each within the scatter of the next).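

In this assay the whole 4-cyanophenyl group can give way to isopropyl, which has no ring at all, and the number still lands level with the two compounds that keep an aromatic ring on this amide-type nitrogen: a 1.8-fold lower number from compound 3 to compound 4 (0.24 log units; within the scatter) and a 1.5-fold lower number from compound 2 to compound 4 (0.18 log units; within the scatter) both lie within the scatter. So an aromatic ring at this position is not what separates these compounds, since three quite different groups read alike and only compound 1 stands apart, with an 8.0-fold higher number from compound 1 to compound 4 (0.90 log units; beyond the scatter) as the third step beyond the scatter away from it. Nothing at hand explains why the 4-cyanophenyl group stands apart from the other three.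

Still open, going by these compounds, is whether the nitrile needs the phenyl ring to keep the number low, a question that a cyanomethyl group on this nitrogen would address. Equally open, on these data alone, is whether a phenyl ring carrying a carboxylic acid or an amine instead of the nitrile would read like compound 1 or like the other three.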